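A few compounds are considered here, and "the series" means these few. Any claim that something is new, unique, unknown or untested is made for them only; others in the source may bear on it.

Measured compounds:
compound 1 `O=C(CCCCCCc1ccccc1)c1ncon1`, 7 nM
compound 2 `O=C(CCCCCCc1ccccc1)c1noc(-c2ccco2)n1`, 8.5 nM

Compound 1 and compound 2 share a core that carries a carbonyl and a saturated chain ending in a phenyl ring. In an assay for inhibition of Fatty-acid amide hydrolase 1 (Rattus norvegicus), at pH 9.0 (on this read-out higher numbers stand for weaker inhibition and lower numbers for stronger inhibition), compound 1 gives 7 nM, the lowest of the two numbers shown, and compound 2 gives 8.5 nM. Among the measured compounds shown here, the only measured step, a 1.2-fold higher number from compound 1 to compound 2 (0.08 log units; within the scatter), concerns a furan-2-yl placed on an aromatic carbon of the ring and lies within the scatter.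

Compound 3 `O=C(CCCCCCc1ccccc1)c1nnn[nH]1` is not yet measured. It differs from compound 1 as follows: 1H-tetrazol-5-yl in place of 1,2,4-oxadiazol-3-yl on a carbonyl carbon. For the measured compounds named here, no measured step touches this position, so the single step from compound 1 to compound 2 gives no guide to it, and the direction and size of the change in this assay remain open; a step beyond the scatter in either direction is possible. Compound 3 is therefore expected to give 150 nM, between 15 nM and 1500 nM, an estimated step of a 21-fold higher number from compound 1 to compound 3 (1.33 log units; beyond the scatter).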

Compound 3, inhibition constant: > 1000 nM
Compound 3: a limit, no number; the forecaster's own chance of this, stated with the estimate: 5%; middle value at least 6.6-fold (0.82 log units) away from the limit.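

Replacing the 1,2,4-oxadiazol-3-yl on the carbonyl carbon with 1H-tetrazol-5-yl gives an at least 140-fold higher number from compound 1 to compound 3 (2.15 log units; beyond the scatter), so this position, which the earlier step did not touch, does not accept every five-membered aromatic ring in this assay. Compound 3 gives > 1000 nM, which is a limit of the assay and not a number. The full size of the step therefore stays unknown: the limit of > 1000 nM in this assay, at which 1 of the 3 values shown sits.

The 1H-tetrazol-5-yl differs from the 1,2,4-oxadiazol-3-yl both in its ring atoms and in carrying a hydrogen-bond donor, and the compounds shown do not separate these two differences. They also leave open how a carboxylic acid or an amide on the same carbonyl carbon would behave in this assay.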